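Anilino series on a shared core: from compound 3 to compound 4

The source may hold more compounds than are shown below. What is called first, only, known or untested is meant among the compounds shown, and "the series" means these compounds.

Measured so far in a functional assay on HeLa cells (Homo sapiens) for inhibition, read by sulforhodamine B assay; on this read-out higher numbers stand for weaker inhibition and lower numbers for stronger inhibition:
compound 1, `O=C1C=C(Nc2ccc(I)cc2)C(=O)c2c1nc1n2[C@H]2OC[C@@H](O)[C@H]2OC1`: 4070 nM
compound 2, `COc1cccc(NC2=CC(=O)c3c(nc4n3[C@H]3OC[C@@H](O)[C@H]3OC4)C2=O)c1`: a limit of the assay, > 8000 nM
compound 3, `O=C1C(Nc2cccc(Cl)c2)=CC(=O)c2c1nc1n2[C@H]2OC[C@@H](O)[C@H]2OC1`: 7970 nM

Compound 3 carries the highest of the two numbers that are numbers at all; compound 1 sits a short way beneath it, and that gap is within the scatter, so neither can be called the weaker inhibitor. The value of compound 2 is a limit and not a number. Within the data shown here, the one counted step, chloro in place of methoxy on an aromatic carbon, gives a number no higher from compound 2 to compound 3 (the limit leaves the size open); its size stays open because of the limit of > 8000 nM in this assay, at which 1 of the 3 values shown sits.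

Compound 4, `CCCc1ccc(NC2=CC(=O)c3c(nc4n3[C@H]3OC[C@@H](O)[C@H]3OC4)C2=O)cc1`, differs from compound 3 by 4-propylphenyl in place of 3-chlorophenyl on an amine nitrogen. Among the measured compounds shown here, no measured step covers this change. Compound 1 shows that another group on the anilino nitrogen leaves the number near that of compound 3, and compound 2 shows only a limit, so there is no basis for expecting a step beyond the scatter. Compound 4 is therefore expected to give about 5000 nM, between 1500 nM and 15000 nM, which is an expected step of a 1.6-fold lower number from compound 3 to compound 4 (0.20 log units; within the scatter).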

Compound 4, half-maximal inhibitory concentration: 6030 nM
Estimate against measurement, compound 4: 1.2-fold (0.08 log units) below; measured number inside the range.
By their numbers in this assay, from the lowest: compounds 1, 4 and 3 (each within the scatter of the next). At a limit, above all of these: compound 2.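

In this assay, among these compounds, replacing the group on the amine nitrogen gives a 1.3-fold lower number from compound 3 to compound 4 (0.12 log units; within the scatter), the first step at this position with a number at both ends. The 3-chlorophenyl and 4-propylphenyl groups therefore cannot be told apart here, even though the entering group carries an all-carbon chain in place of chlorine and the substituent sits at a different ring position. Compound 2 stands at a limit, so its step reads an at least 1.3-fold lower number from compound 2 to compound 4 (0.12 log units; that floor lies within the scatter), and this gives only a floor, with the true size open: the limit of > 8000 nM in this assay, at which 1 of the 4 values shown sits.

Both the substituent and its ring position change in the step to compound 4, so these compounds cannot separate the two changes, and a matched pair such as 4-chlorophenyl against 3-chlorophenyl would be needed to do so. From the compounds shown here alone, it also remains open whether an anilino ring bearing a primary amine, a carboxylic acid or a longer alkyl chain would give a number beyond the scatter of those seen so far on the shared core.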